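Series notes: open-chain amines against a ring amine

The source may report more compounds than this note shows. Statements on the series, on what has been measured and on what is new or still open speak of the compounds shown alone.

For the measured compounds named here, in an assay on HeLa cells for inhibition of sphingosine-1-phosphate transporter SPNS2 (Mus musculus), read by LC-MS, tested at 2 uM (a lower number here means less inhibition, a higher number more inhibition at the concentration tested (going by the name of the read-out)), compound 1 `CCCCCCCCCCc1ccc(-c2noc(CCCN)n2)cc1` gives 67%, while compound 2 `CCCCCCCCCCc1ccc(-c2noc([C@@H]3CCCN3)n2)cc1` gives 21%, the lowest of the two numbers so far. Going by the values given here, the one measured step, a number 46 percentage points lower from compound 1 to compound 2 (beyond the scatter), is large. Compound 3 `CCCCCCCCCCc1ccc(-c2noc(CC[C@@H](N)C(=O)O)n2)cc1` carries the change (3-amino-3-carboxypropyl in place of pyrrolidin-2-yl on an aromatic carbon). This step partly undoes the earlier one, since the open chain returns, yet the added carboxylic acid is untried in this assay, so only the direction is taken from compound 1 and the size is uncertain. A rise beyond the scatter is expected, a number 24 percentage points higher from compound 2 to compound 3 (beyond the scatter), and compound 3 is estimated at 45%, between 15% and 75%.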

Compound 3, a percentage reported as inhibition, at one concentration (the size of the read-out at that concentration, not a potency): 5%
Compound 3: the middle estimate sits 40 percentage points above what was measured; measured number below the stated range.
By their numbers in this assay, from the lowest: compound 3; then compound 2; then compound 1.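

At this position, the open chain does not hold its number once it carries a carboxylic acid: in this assay, carboxy in place of hydrogen on the saturated chain carbon bound to the amine nitrogen gives a number 62 percentage points lower from compound 1 to compound 3 (beyond the scatter). 3-amino-3-carboxypropyl in place of pyrrolidin-2-yl also gives a number 16 percentage points lower from compound 2 to compound 3 (beyond the scatter), so the open chain alone does not lift the number above that of the ring amine. Nothing available explains either step.

Open, as far as these compounds go, is whether a methyl ester or primary amide in place of the carboxylic acid, or a longer chain carrying the amine, would recover the number.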